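Double-bond geometry in a hydroxylated pair

The compounds below may be only part of what the source reports. "The series", "measured", "known", "first", "only" and "open" are said of these compounds alone.

In a functional assay on HL-60 cells (Homo sapiens) for cytotoxicity, read by MTT assay, with a stated time of 46 h (on this read-out lower numbers stand for stronger inhibition and higher numbers for weaker inhibition), compound 1 (`O=C1/C(=C\c2ccccc2)C(c2ccccc2)Oc2ccccc21`) gives 27300 nM and compound 2 (`O=C1/C(=C/c2ccccc2)C(c2ccccc2)Oc2ccc(O)cc21`) gives 5800 nM as the lower of the two numbers. Compound 3 (`O=C1/C(=C\c2ccccc2)C(c2ccccc2)Oc2ccc(O)cc21`) differs from compound 2 by the two compounds have the same atoms and bonds; at least one stereo element is drawn with a configuration in one of them and without one in the other: 1 of 2 stereo elements differ; a double bond is drawn E in compound 2 and Z in compound 3 with the same atoms and bonds, a double bond being drawn E in compound 2 and Z in compound 3. Within the data shown here, no measured step isolates this change. Among the measured compounds shown here, the only guide is compound 1 at 27300 nM with the double bond drawn as in compound 3. The expected change is a 1.9-fold higher number from compound 2 to compound 3 (0.28 log units; within the scatter) toward a higher number in this assay and near the edge of the scatter. Compound 3 is estimated at 11000 nM with an expected range from 3500 nM to 30000 nM in this read-out.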

Compound 3, half-maximal inhibitory concentration: 7300 nM
Beside the measured number, compound 3's estimate is 1.5-fold (0.18 log units) above it, within the range that was stated.
By their numbers in this assay, from the lowest: compounds 2 and 3 (each within the scatter of the next); then compound 1.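

The change of the double bond from E to Z gives a 1.3-fold higher number from compound 2 to compound 3 (0.10 log units; within the scatter) in this assay, so the two drawn geometries are not separated on this read-out. With the double bond drawn the same way, hydroxy in place of hydrogen on an aromatic carbon gives a 3.7-fold lower number from compound 1 to compound 3 (0.57 log units; beyond the scatter), a step that isolates this change. The geometry step needs caution because of how the pair is drawn: the fact that one of compounds 2 and 3 is drawn with a defined configuration and the other without, at the place where they differ. The compounds shown leave open how an amine or a carboxylic acid in place of the hydroxy would read, and whether the double-bond geometry matters without the hydroxy.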